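The source may hold more compounds than are shown below. What is called first, only, known or untested is meant among the compounds shown, and "the series" means these compounds.

Measured so far:
- compound 1 `CN(C)C1(Cc2ccccc2)CCN(c2cc(C(F)(F)F)ccc2CNC(=O)Nc2ccc(CO)c(F)c2)CC1` — 27.9 nM
- compound 2 `CN(C)C1(Cc2ccccc2)CCN(c2cc(C(F)(F)F)ccc2CNC(=O)Nc2cccc3cnccc23)CC1` — 0.67 nM

In an assay on CHO cells for displacement of a labelled ligand from transient receptor potential cation channel subfamily V member 1 (Homo sapiens), read by scintillation counting, with a stated time of 60 min (a lower number here means a stronger inhibitor, a higher number a weaker inhibitor), compound 2 gives the lowest of the two numbers, well apart from compound 1, as the step of a 42-fold lower number from compound 1 to compound 2 (1.62 log units; beyond the scatter) shows. Compound 3 `CN(C)C1(Cc2ccccc2)CCN(c2cc(C(F)(F)F)ccc2CNC(=O)Nc2cccc3ncccc23)CC1` keeps the same atoms and differs only by quinolin-5-yl in place of isoquinolin-5-yl on an amide-type nitrogen. Among the compounds with values here, no measured step swaps one bicyclic group for the other; the single step from compound 1 to compound 2 only shows that the isoquinolin-5-yl group outperforms a substituted phenyl. For compound 3 a modest weakening is therefore expected, a 4.5-fold higher number from compound 2 to compound 3 (0.65 log units; beyond the scatter), giving an estimated 3 nM with a range from 0.7 nM to 15 nM.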

Compound 3, inhibition constant: 10.8 nM
Compound 3: middle estimate off by 3.6-fold (0.56 log units), on the low side; low and high end bracket the measured number.
By their numbers in this assay, from the lowest: compound 2; then compound 3; then compound 1.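

In this assay, the same atoms arranged differently give very different results: a 16-fold higher number from compound 2 to compound 3 (1.21 log units; beyond the scatter), even though isoquinolin-5-yl and quinolin-5-yl differ only in where the ring nitrogen lies. Having two fused rings therefore does not by itself deliver the whole gain over 3-fluoro-4-(hydroxymethyl)phenyl, since quinolin-5-yl gives only a 2.6-fold lower number from compound 1 to compound 3 (0.41 log units; beyond the scatter). Nothing available here explains this difference between the two groups.

From the compounds shown here alone, it remains open whether naphthalen-1-yl, with carbon in place of the ring nitrogen, would fall nearer compound 2 or compound 3. Going by these compounds, the effect of adding an amine to either bicyclic group also remains open.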